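The compounds below may be only part of what the source reports. "The series", "measured", "known", "first", "only" and "open" are said of these compounds alone.

Compound 1 `CCCc1nc(C)c2cnnc(O)n12` and compound 2 `Cc1nc(C(C)(C)C)n2c(O)nncc12` share a small fused core. In a functional assay for inhibition, with Homo sapiens as the target (a higher number here means a weaker inhibitor, a lower number a stronger inhibitor), compound 1 gives 56800 nM, and compound 2 gives 31000 nM. Among the compounds with values here, the single step that can be read between measured compounds, a 1.8-fold lower number from compound 1 to compound 2 (0.26 log units; within the scatter), swaps one alkyl group for another on the core and stays within the scatter, so it shows no real change. Compound 3 `CCc1nc(C)c2c(-c3ccccc3)nnc(O)n12` carries a phenyl on its fused core. In this assay compound 3 sits at a limit of the assay, > 48000 nM. The line the limit of > 48000 nM in this assay, at which 1 of the 3 values shown sits, shows where that limit lies. Compound 4 `CCc1nc(C)c2cnnc(O)n12` has not yet been measured. It differs from compound 3 by hydrogen in place of phenyl on an aromatic carbon. Within the data shown here, none of the measured steps removes a phenyl, so no step bears directly on this change. What the data do offer is that compound 1 and compound 2, which also lack the phenyl, both give numbers in the weak range. Compound 4 is therefore expected to give a number in that same weak range, so the step that the limit leaves unreadable from compound 3 to compound 4 is expected to be small. The estimate for compound 4 in this assay is 50000 nM, with a range from 20000 nM to 150000 nM.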

Compound 4, half-maximal inhibitory concentration: > 48000 nM
Compound 4: no number, only a limit (the forecaster's own chance of this, stated with the estimate: 35%); the middle value is on the limit's open side.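

Swapping phenyl for hydrogen on this aromatic carbon, para to a hydroxy group, brings no readable strengthening: compound 4 rests at a limit of the assay, as compound 3 does, so the phenyl is not shown to be what keeps compound 3 weak. The only step that can be read is an at least 1.5-fold higher number from compound 2 to compound 4 (0.18 log units; that floor lies within the scatter), so ethyl in place of tert-butyl on an aromatic carbon is not shown to make a real difference, while the steps to compound 4 from compound 3 and from compound 1 cannot be read. The small compounds without a phenyl and the one with it now meet at the same boundary, which is why the size of the phenyl step stays hidden: the limit of > 48000 nM in this assay, at which 2 of the 4 values shown sit.

The compounds shown leave open whether any other group on this aromatic carbon, such as an amine, a methoxy group or a carboxylic acid, would give a number clear of the limit. They also leave open whether a longer chain on the aromatic carbon that carries the ethyl of compound 4 would move the number at all.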